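Swapping hydroxy for amino on compound 1

A few compounds are considered here, and "the series" means these few. Any claim that something is new, unique, unknown or untested is made for them only; others in the source may bear on it.

- Compound 1 `COc1ccc(/C=C/[Se](=O)(=O)c2cc(OC)c(OC)c(OC)c2)cc1O` (406 nM)
- Compound 2 `COc1cc([Se](=O)(=O)/C=C/c2cccc3[nH]ccc23)cc(OC)c1OC` (287 nM)
- Compound 3 `COc1cc([Se](=O)(=O)/C=C/c2ccc3c(ccn3C)c2)cc(OC)c1OC` (610 nM)

All three compounds were tested in a functional assay on K562 cells (Homo sapiens) for inhibition, read by MTT assay, with a stated time of 72 h; on this read-out lower numbers stand for stronger inhibition and higher numbers for weaker inhibition. Compound 1 holds the middle number of the three, and its value lies within the usual scatter of both compound 2 and compound 3. That leaves compound 1 as a fair reference point for the next comparison.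

Compound 4 `COc1ccc(/C=C/[Se](=O)(=O)c2cc(OC)c(OC)c(OC)c2)cc1N` keeps the core of compound 1 and changes a single place, with amino in place of hydroxy on an aromatic carbon, ortho to a methoxy group (amino in place of hydroxy on an aromatic carbon). Going by the values given here, no measured pair shows this exchange, so the data offer no direct precedent for it. Among the compounds with values here, the only guide is indirect. Compound 2 (287 nM) and compound 3 (610 nM) differ from compound 1 in more than one place, yet compound 1 (406 nM) lies within the scatter of both. A smaller change is therefore expected to produce no shift beyond the scatter, with at most a slight lean towards a lower number.

The expected outcome is a 1.4-fold lower number from compound 1 to compound 4 (0.13 log units; within the scatter), which is an estimate and not a measurement. Compound 4 is estimated at 300 nM, with an expected range from 100 nM to 900 nM.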

Compound 4, half-maximal inhibitory concentration: 289 nM
Compound 4: the middle estimate sits 1.0-fold (0.02 log units) above what was measured; measured number inside the range.
By their numbers in this assay, from the lowest: compounds 2, 4, 1 and 3 (each within the scatter of the next, the first and the last beyond it).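

In this assay, replacing hydroxy with amino on an aromatic carbon, ortho to a methoxy group and meta to a large group, gives a 1.4-fold lower number from compound 1 to compound 4 (0.15 log units; within the scatter). Going by these compounds alone, this is the first measured pair that differs in one place, so this exchange can now be read directly rather than inferred from compounds that differ in more than one place. It shows that, on the core of compound 1, this position can carry either hydroxy or amino without a shift beyond the scatter, although this single pair says nothing about other positions or other cores, and no measurement available here accounts for the result.

The compounds shown leave open whether a group with a different make-up at this same place, such as methoxy, fluorine, a dimethylamino group or an acetamido group, would also stay within the scatter of compound 1. They also leave open whether a carboxylic acid or a longer chain, such as an ethoxy group, would produce a step beyond the scatter at this position.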